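This account rests on a few compounds, and the source may have more. Where it says the series, first, only, none or still open, it means among the compounds named here.

Compound 2, `CCn1c(=O)n(C2OC(CO)[C@@H](O)[C@H]2O)c2nc(N)nc(O)c21`, is a small analogue in which an ethyl chain sits on an aromatic nitrogen of the shared core. Within the data shown here, in a functional assay (B cells) with Mus musculus as the target (a lower number here means that less compound is needed, a higher number that more compound is needed for the effect), compound 2 gives 15 uM, the lowest number of the two measured so far. Its nearest neighbour is compound 1, `CN(C)CCCn1c(=O)n(C2OC(CO)[C@@H](O)[C@H]2O)c2nc(N)nc(O)c21`, which carries a longer chain on that nitrogen and gives 194 uM. Among the measured compounds shown here, the one measured step, a 13-fold lower number from compound 1 to compound 2 (1.11 log units; beyond the scatter), shows that taking a group off this chain lowered the number considerably.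

Compound 3, `NC(=O)Cn1c(=O)n(C2OC(CO)[C@@H](O)[C@H]2O)c2nc(N)nc(O)c21`, changes the same chain in another way: carbamoyl in place of methyl on a saturated chain carbon bound to an aromatic nitrogen. For the measured compounds named here, the only step that bears on it is a 13-fold lower number from compound 1 to compound 2 (1.11 log units; beyond the scatter), which ran the other way, with a group being added rather than removed, and nothing measured shows what a carbamoyl group in particular does here. Since adding atoms to this chain raised the number in that step, compound 3 is expected to give a higher number than compound 2, by a step of about a 2.7-fold higher number from compound 2 to compound 3 (0.43 log units; beyond the scatter). The estimate for compound 3 in this assay is 40 uM, with a range from 12 uM to 150 uM.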

Compound 3, concentration for half-maximal effect: 190 uM
The estimate for compound 3 lay 4.8-fold (0.68 log units) below the measured number; measured number outside the range, above it.
By their numbers in this assay, from the lowest: compound 2; then compounds 3 and 1 (each within the scatter of the next).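

In this assay, carbamoyl in place of methyl on a saturated chain carbon bound to an aromatic nitrogen gives a 13-fold higher number from compound 2 to compound 3 (1.10 log units; beyond the scatter) and so shows that a change of only a few atoms at this position can produce a large step. Two quite different groups also end up level here, with a 1.0-fold lower number from compound 1 to compound 3 (0.01 log units; within the scatter) and a step within the scatter, so that among these three compounds only the ethyl chain of compound 2 stands apart. No measurement at hand explains this behaviour.

The compounds shown leave open whether the number rises with any chain larger than ethyl, or only with chains that end in an amine or an amide. A plain propyl chain, a chain ending in a carboxylic acid, or a single methyl on this nitrogen would help to separate these readings.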